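Benzyl Swap to a Sulfamoyl Group, Cytotoxicity Expected Unchanged

The source may hold more compounds than are shown below. What is called first, only, known or untested is meant among the compounds shown, and "the series" means these compounds.

Compound 1, `CCOC(=O)c1cnc(N2CCN(Cc3ccccc3C#N)CC2)nc1Oc1c(C)cc(-c2ccc(C#N)cc2)cc1C`: > 125000 nM, a limit of the assay
Compound 2, `CCOC(=O)c1cnc(N2CCN(Cc3ccccc3C(F)(F)F)CC2)nc1Oc1c(C)cc(-c2ccc(C#N)cc2)cc1C`: > 125000 nM, a limit of the assay
Compound 3, `CCOC(=O)c1cnc(N2CCN(Cc3cccc(Br)c3)CC2)nc1Oc1c(C)cc(-c2ccc(C#N)cc2)cc1C`: > 125000 nM, a limit of the assay

In an ADME assay on MT4 cells (Homo sapiens) for cytotoxicity, read by MTT assay, with a stated time of 4 days (on this read-out lower numbers stand for higher toxicity in this test and higher numbers for lower toxicity in this test), compound 1 gives > 125000 nM, which is a limit of the assay rather than a number. Compound 2 likewise gives > 125000 nM, again a limit. Compound 3, the starting point here, gives > 125000 nM, also only a limit, so its true value is known only to lie beyond that point. All three sit at the limit of > 125000 nM in this assay, at which 3 of the 3 values shown sit. For that reason the measured steps say little about size: a step that the two limits leave unreadable from compound 1 to compound 2, a step that the two limits leave unreadable from compound 1 to compound 3 and a step that the two limits leave unreadable from compound 2 to compound 3 are all unreadable, yet each of them swapped the group at the same place and left the read-out at the limit.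

Compound 4, `CCOC(=O)c1cnc(N2CCN(Cc3ccc(S(N)(=O)=O)cc3)CC2)nc1Oc1c(C)cc(-c2ccc(C#N)cc2)cc1C`, differs from compound 3 by 4-sulfamoylphenyl in place of 3-bromophenyl on a saturated chain carbon bound to an amine nitrogen in a ring. This is the same kind of exchange at the same place as the three unreadable steps, none of which moved the value off the limit. Compound 4 is therefore expected to show no change beyond the scatter, the step that the limit leaves unreadable from compound 3 to compound 4 being essentially flat. Compound 4 is estimated at 150000 nM in this assay, within a range of 90000 nM to 400000 nM, most likely reported once more as a limit.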

Compound 4, half-maximal cytotoxic concentration: >= 7930 nM
Compound 4 gave a limit, no number (the forecaster's own chance of this, stated with the estimate: 85%); the middle value does not contradict the limit.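

Compound 4 gives only a limit of the assay, and so do compound 1, compound 2 and compound 3; the steps from each of those three compounds to compound 4 cannot be read. The compounds shown leave open how toxic any of them truly is in this assay, and whether changing the benzyl group alters that at all.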